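Changing the group on the carbonyl carbon: working notes

The source may hold more compounds than are shown below. What is called first, only, known or untested is meant among the compounds shown, and "the series" means these compounds.

In an ADME assay on MT4 cells (Homo sapiens) for cytotoxicity, read by MTT assay (a higher number here means that more compound is tolerated, a lower number that less compound is tolerated), compound 1 `O=C1c2ccccc2C(=O)N1CCOC(=S)N(C(=O)c1cc(F)cc(F)c1)c1ccc(Cl)cc1` gives 59000 nM, compound 2 `O=C1c2ccccc2C(=O)N1CCOC(=S)N(C(=O)c1ccc(Cl)c(Cl)c1)c1ccc(Cl)cc1` gives 35000 nM and compound 3 `O=C1c2ccccc2C(=O)N1CCOC(=S)N(C(=O)c1cc([N+](=O)[O-])ccc1Cl)c1ccc(Cl)cc1` gives 45000 nM. Compound 3 therefore lies within the scatter of both other compounds, and the three values cannot be separated.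

Compound 4 `O=C1c2ccccc2C(=O)N1CCOC(=S)N(C(=O)c1cc2ccccc2s1)c1ccc(Cl)cc1` differs from compound 3 at one place: 1-benzothiophen-2-yl in place of 2-chloro-5-nitrophenyl on a carbonyl carbon. In words, 1-benzothiophen-2-yl stands in place of 2-chloro-5-nitrophenyl on a carbonyl carbon.

Three measured steps change the group at this same place: a 1.7-fold lower number from compound 1 to compound 2 (0.23 log units; within the scatter), a 1.3-fold lower number from compound 1 to compound 3 (0.12 log units; within the scatter) and a 1.3-fold higher number from compound 2 to compound 3 (0.11 log units; within the scatter). All three lie within the scatter, so no step beyond the scatter is expected in this assay, in either direction. Within the data shown here, this expectation is only an extrapolation, since no measured compound carries 1-benzothiophen-2-yl.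

The expected step is a 1.1-fold lower number from compound 3 to compound 4 (0.03 log units; within the scatter), which would stay within the scatter. Compound 4 is estimated at 42000 nM, with an expected range of 20000 nM to 85000 nM.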

Compound 4, half-maximal cytotoxic concentration: 56000 nM
The estimate for compound 4 lay 1.3-fold (0.12 log units) below the measured number, and the stated range covers the measured number.
By their numbers in this assay, from the lowest: compounds 2, 3, 4 and 1 (each within the scatter of the next).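

In this assay the change to 1-benzothiophen-2-yl brings a five-membered aromatic ring with a sulfur atom onto the carbonyl carbon, and compound 4 stays within the scatter of all three substituted-phenyl compounds (a 1.2-fold higher number from compound 3 to compound 4 (0.09 log units; within the scatter)) and (a 1.6-fold higher number from compound 2 to compound 4 (0.20 log units; within the scatter)) and (a 1.1-fold lower number from compound 1 to compound 4 (0.02 log units; within the scatter)). The range of groups tolerated at this place without a step beyond the scatter therefore extends past substituted phenyl groups to one with two aromatic rings and no chlorine, fluorine or nitro substituent. Nothing available here bears on why these values do not separate.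

Going by these compounds, whether a phenyl carrying a carboxylic acid or an amine, or a plain hexyl chain, on this carbonyl carbon would give a step beyond the scatter stays open. On these data alone, all four compounds share the rest of the core, so the effect of a change elsewhere on it also stays open.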